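Amino substitution on the fused ring of two weak growth inhibitors

This account rests on a few compounds, and the source may have more. Where it says the series, first, only, none or still open, it means among the compounds named here.

Compound 1 `CCn1cc(-c2nc3ccccc3[nH]2)c(=O)c2cc(F)c(N3CCNCC3)cc21` and compound 2 `CCn1cc(-c2nc3ccccc3[nH]2)c(=O)c2cc(F)c(N3CCNCC3)nc21` share most of their structure; the difference between the two cores is not broken down here. In a functional assay on HeLa cells (Homo sapiens) for cytotoxicity, read by sulforhodamine B assay, with a stated time of 48 h (a lower number here means a stronger inhibitor of growth, a higher number a weaker inhibitor of growth), compound 1 gives only a limit, > 10000 nM. In this assay, among the measured compounds shown here, compound 2 gives 6400 nM, the only plain number so far. Compound 3 `CCn1cc(-c2nc3ccc(N)cc3[nH]2)c(=O)c2cc(F)c(N3CCNCC3)cc21` carries the change amino in place of hydrogen on an aromatic carbon on the core of compound 1. In this assay compound 3 likewise gives only a limit, > 10000 nM. The step that the two limits leave unreadable from compound 1 to compound 3, since the limit of > 10000 nM in this assay, at which 2 of the 3 values shown sit, covers both of its ends. Compound 4 `CCn1cc(-c2nc3ccc(N)cc3[nH]2)c(=O)c2cc(F)c(N3CCNCC3)nc21` makes the same change, (amino in place of hydrogen on an aromatic carbon), on compound 2. Because the step that the two limits leave unreadable from compound 1 to compound 3 shows no readable size, compound 4 is expected to stay close to its parent, with a step of about a 1.1-fold higher number from compound 2 to compound 4 (0.04 log units; within the scatter) in this assay. Compound 4 is estimated at 7000 nM, between 2500 nM and 20000 nM.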

Compound 4, concentration for 50% growth inhibition: > 10000 nM
Compound 4: a limit, no number; the forecaster's own chance of this, stated with the estimate: 40%; at least 1.4-fold (0.15 log units) between middle value and limit.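

In this assay compound 4 gives > 10000 nM, which is a limit and not a number. Amino in place of hydrogen on an aromatic carbon gives an at least 1.5-fold higher number from compound 2 to compound 4 (0.19 log units; that floor lies within the scatter), so the change brings no stronger inhibition of growth on this core, while its true size stays unknown. The matching step on the core of compound 1 cannot be read, so the change can be neither confirmed nor rejected as carrying over from one core to the other: the limit of > 10000 nM in this assay, at which 3 of the 4 values shown sit.

The compounds shown leave open whether a carboxylic acid or a nitrile on the same aromatic carbon would give a plain number in this assay. They also leave open whether the amino step has a readable size on either core.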